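Benzyl in place of hydrogen on the oxygen of compound 2

A few compounds are considered here, and "the series" means these few. Any claim that something is new, unique, unknown or untested is made for them only; others in the source may bear on it.

Compound 1, `COc1cccc(COc2ccc3cc(C(=O)/C=C/c4cc(OC)ccc4OC)c(=O)oc3c2)c1`, in a functional assay on K562 cells (Homo sapiens) for cytotoxicity, read by MTT assay, with a stated time of 72 h (a lower number here means a stronger inhibitor, a higher number a weaker inhibitor), gives > 100000 nM; this is a limit of the assay, not a number.
Compound 2, `COc1cccc(/C=C/C(=O)c2cc3cc(O)ccc3oc2=O)c1OC`, in this assay gives 17300 nM.
Compound 3, `COc1cc(/C=C/C(=O)c2cc3ccc(O)cc3oc2=O)cc(OC)c1OC`, in this assay gives 7300 nM.

Among the two numbers, compound 2 stands highest, with compound 3 nearest and beyond the scatter. Compound 4, `COc1cccc(/C=C/C(=O)c2cc3cc(OCc4ccccc4)ccc3oc2=O)c1OC`, has not yet been measured in this assay. It differs from compound 2 by benzyl in place of hydrogen on an oxygen on an aromatic ring. Going by the values given here, no measured pair shows this change, so the size of the step is open. The expectation for compound 4 is 30000 nM, with a range from 8000 nM to 100000 nM. This expected step a 1.7-fold higher number from compound 2 to compound 4 (0.24 log units; within the scatter) is a modest weakening, not far beyond the scatter.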

Compound 4, half-maximal inhibitory concentration: 48900 nM
Compound 4: the middle estimate sits 1.6-fold (0.21 log units) below what was measured; the range from low to high includes it.
By their numbers in this assay, from the lowest: compound 3; then compound 2; then compound 4. At a limit, above all of these: compound 1.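

In this assay, going by these compounds alone, benzyl in place of hydrogen on this oxygen gives the first readable step for the change, and it weakens the compound (a 2.8-fold higher number from compound 2 to compound 4 (0.45 log units; beyond the scatter)). Hydroxy to benzyloxy at this place is therefore not neutral, though compound 4 still returns a number and not a limit, which sets it apart from the one compound that reaches the limit: the limit of > 100000 nM in this assay, at which 1 of the 4 values shown sits.

As far as these compounds go, whether a smaller or charged group on this oxygen, such as methyl, a dimethylaminoethyl chain or a carboxylic acid on a short chain, would keep the number of compound 2 stays open. From the compounds shown here alone, whether the same step holds on the core of compound 3 also stays open.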